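The source may report more compounds than this note shows. Statements on the series, on what has been measured and on what is new or still open speak of the compounds shown alone.

Measured so far:
- compound 1, `c1cncc(-c2ccccc2OCC2=NCCN2)c1` — in a functional assay for activation of Alpha-1D adrenergic receptor (Homo sapiens), read by calcium flux (on this read-out higher numbers stand for an effect only at larger amounts of compound and lower numbers for an effect already at smaller amounts), compound 1 gives 158 nM
- compound 2, `Cc1ccc(-c2ccccc2OCC2=NCCN2)s1` — in this assay compound 2 gives < 100000 nM, which is a limit of the assay and not a number

Where compound 2 stands: its reading in this assay is only a limit, as noted in the limit of < 100000 nM in this assay, at which 1 of the 2 values shown sits, so its place relative to compound 1 cannot be fixed. Among the measured compounds shown here, the one measured step, a step that the limit leaves unreadable from compound 1 to compound 2, is therefore of unreadable size.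

Compound 3, `Cn1nccc1-c1ccccc1OCC1=NCCN1`, is not yet measured in this assay. It differs from compound 2 by 1-methyl-1H-pyrazol-5-yl in place of 5-methylthiophen-2-yl on an aromatic carbon. For the measured compounds named here, no measured step bears directly on this change; the step from compound 1 to compound 2 covers a different exchange and is itself unreadable. What remains is that compound 1, carrying a nitrogen-containing aromatic ring at the same place, gives 158 nM in this assay, and compound 3 also carries a nitrogen-containing aromatic ring there. On that basis the step that the limit leaves unreadable from compound 2 to compound 3 is expected, though its size cannot be pinned down against a limit. Compound 3 is estimated at 600 nM in this assay, in a wide range from 60 nM to 8000 nM.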

Compound 3, half-maximal effective concentration: < 100000 nM
Compound 3: a limit, no number (the forecaster's own chance of this, stated with the estimate: 20%); the middle value lies beyond the limit too.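

Compound 3 reads only as a limit in this assay, not as a number, so no step from compound 1 or compound 2 to compound 3 can be read, and all steps among these compounds stay unreadable: the limit of < 100000 nM in this assay, at which 2 of the 3 values shown sit.

The compounds shown leave open how compound 2 and compound 3 compare with each other and how far either lies from compound 1.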